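A few compounds are considered here, and "the series" means these few. Any claim that something is new, unique, unknown or untested is made for them only; others in the source may bear on it.

Measured so far:
compound 1 `Cc1nc(S(C)(=O)=O)ccc1Oc1ncnc(OC2CCN(C(=O)OC3(C(F)(F)F)COC3)CC2)c1F` — 342 nM
compound 2 `Cc1nc(S(C)(=O)=O)ccc1Oc1ncnc(OC2CCN(C(=O)SC(C)C)CC2)c1F` — 41.3 nM
compound 3 `Cc1nc(S(C)(=O)=O)ccc1Oc1ncnc(OC2CCN(C(=O)SC3CC3)CC2)c1F` — 126 nM

All numbers come from a functional assay on isolated protein for inhibition of Glucose-dependent insulinotropic receptor (Rattus norvegicus), read by HTRF and cAMP accumulation; a higher number here means that more compound is needed for the effect, a lower number that less compound is needed. Compound 3 stands second highest of the three: a 3.1-fold higher number from compound 2 to compound 3 (0.48 log units; beyond the scatter), while a 2.7-fold lower number from compound 1 to compound 3 (0.43 log units; beyond the scatter). Compound 4 `Cc1nc(S(C)(=O)=O)ccc1Oc1ncnc(OC2CCN(C(=O)C3CCCC3)CC2)c1F` differs from compound 3 in one place: a group of 5 heavy atoms (5 carbon; one five-membered non-aromatic ring of carbon only) in place of a group of 4 heavy atoms (3 carbon, 1 sulfur; one three-membered non-aromatic ring of carbon only), on a carbonyl carbon. Among the measured compounds shown here, the steps that bear on this all vary the group on the carbonyl carbon, an 8.3-fold lower number from compound 1 to compound 2 (0.92 log units; beyond the scatter), a 2.7-fold lower number from compound 1 to compound 3 (0.43 log units; beyond the scatter) and a 3.1-fold higher number from compound 2 to compound 3 (0.48 log units; beyond the scatter), each modest in size. For the measured compounds named here, no measured step brings in cyclopentyl, so the direction is open; a modest step either way remains possible, and a small lowering is taken as the working expectation, a 1.4-fold lower number from compound 3 to compound 4 (0.15 log units; within the scatter). Compound 4 is therefore expected to give 90 nM in this assay, within a range of 30 nM to 300 nM.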

Compound 4, half-maximal effective concentration: 407 nM
Compound 4: the middle estimate sits 4.5-fold (0.66 log units) below what was measured; measured number above the stated range.
By their numbers in this assay, from the lowest: compound 2; then compound 3; then compounds 1 and 4 (each within the scatter of the next).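

Cyclopentyl, the first group here attached to the carbonyl carbon through a ring carbon, reads clearly worse than both sulfur-linked groups (in a 3.2-fold higher number from compound 3 to compound 4 (0.51 log units; beyond the scatter), and in a 9.9-fold higher number from compound 2 to compound 4 (0.99 log units; beyond the scatter)). Against the (3-(trifluoromethyl)oxetan-3-yl)oxy group it gives no separation (a 1.2-fold higher number from compound 1 to compound 4 (0.08 log units; within the scatter)), so two quite different groups fall at the same level. No measured evidence accounts for these steps.

Among the compounds shown here, no pair carries the same group with and without sulfur, so the part played by the sulfur link stays open. As far as these compounds go, how cyclopentylsulfanyl or an amine on this carbonyl carbon would read also remains unknown.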